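Trifluoromethyl on the terminal phenyl of compound 2

The compounds below may be only part of what the source reports. "The series", "measured", "known", "first", "only" and "open" are said of these compounds alone.

Among the measured compounds shown here, in a functional assay on KB cells (Homo sapiens) for inhibition, read by sulforhodamine B assay (a lower number here means a stronger inhibitor of growth, a higher number a weaker inhibitor of growth), compound 1 (`c1ccc(-c2ccc(-c3ccc(-c4nc5ccccc5[nH]4)cc3)cc2)cc1`) gives 39700 nM and compound 2 (`Oc1cccc2[nH]c(-c3ccc(-c4ccc(-c5ccccc5)cc4)cc3)nc12`) gives 4010 nM as the lower of the only two numbers so far. For the measured compounds named here, the single measured step is a 9.9-fold lower number from compound 1 to compound 2 (1.00 log units; beyond the scatter) and it came with hydroxy in place of hydrogen on an aromatic carbon. It is modest in size but beyond the scatter.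

Compound 3 (`Oc1cccc2[nH]c(-c3ccc(-c4ccc(-c5ccc(C(F)(F)F)cc5)cc4)cc3)nc12`) keeps that hydroxy and differs from compound 2 by trifluoromethyl in place of hydrogen on an aromatic carbon in a ring where the group sits para to a large group. The change is phenyl to 4-(trifluoromethyl)phenyl. Going by the values given here, no measured step touches this place, so a 9.9-fold lower number from compound 1 to compound 2 (1.00 log units; beyond the scatter) serves only as a yardstick for a modest move and gives no direction. The central expectation is therefore no change beyond the scatter, with real uncertainty on both sides. For compound 3 the expected step is a 1.3-fold lower number from compound 2 to compound 3 (0.13 log units; within the scatter) in this assay as an estimate only. Compound 3 is estimated at 3000 nM (expected range 800 nM to 12000 nM) in this assay when measured.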

Compound 3, concentration for 50% growth inhibition: 4320 nM
The estimate for compound 3 lay 1.4-fold (0.16 log units) below the measured number; measured number inside the range.
By their numbers in this assay, from the lowest: compounds 2 and 3 (each within the scatter of the next); then compound 1.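

In this assay, the change from phenyl to 4-(trifluoromethyl)phenyl gives a 1.1-fold higher number from compound 2 to compound 3 (0.03 log units; within the scatter), so this place, para to a large group, accepts the four added heavy atoms without a shift beyond the scatter. Among the compounds shown here, the earlier step showed only that the number responds to hydroxy in place of hydrogen on an aromatic carbon; this one is the first reading at a second place, and compound 3 stays level with compound 2 while keeping that hydroxy. No available measurement bears on why the number holds at this place.

The compounds shown do not tell whether this place is as indifferent to other groups, such as an amine, a carboxylic acid or a methoxy, since trifluoromethyl is the only group read there so far. They also leave open whether trifluoromethyl at the same place would read the same on the core of compound 1, which lacks the hydroxy, or whether the flat result holds only with the hydroxy present.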